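This account rests on a few compounds, and the source may have more. Where it says the series, first, only, none or still open, it means among the compounds named here.

In an ADME assay on HEK293 cells (Homo sapiens) for cytotoxicity, read by MTT assay, with a stated time of 24 h (on this read-out lower numbers stand for stronger inhibition and higher numbers for weaker inhibition), compound 1 (`CN(C)CCCNc1nc2cc([N+](=O)[O-])ccc2nc1NCc1ccc(C(F)(F)F)cc1`) gives 5.66 ug/mL and compound 2 (`CN1CCN(CCCNc2nc3cc([N+](=O)[O-])ccc3nc2NCc2ccc(C(F)(F)F)cc2)CC1`) gives 9.53 ug/mL, so the two lie within the scatter of each other. Compound 3 (`CN(C)CCCCNc1nc2cc([N+](=O)[O-])ccc2nc1NCc1ccc(C(F)(F)F)cc1`) is unmeasured and differs from compound 1 as follows: (dimethylamino)methyl in place of dimethylamino on a saturated chain carbon, three bonds along the chain from a nitrogen on an aromatic ring. Among the measured compounds shown here, only one measured step bears on this, a 1.7-fold higher number from compound 1 to compound 2 (0.23 log units; within the scatter), and it stays within the scatter. That step places 4-methylpiperazin-1-yl in place of dimethylamino at the same place, so it is only a loose guide. No step beyond the scatter is expected in this assay. The estimated step is a 1.0-fold lower number from compound 1 to compound 3 (0.01 log units; within the scatter). Compound 3 is expected at 5.5 ug/mL, with an estimated range of 2.5 ug/mL to 12 ug/mL.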

Compound 3, half-maximal inhibitory concentration: 9.73 ug/mL
Compound 3: middle estimate off by 1.8-fold (0.25 log units), on the low side; the range from low to high includes it.
By their numbers in this assay, from the lowest: compounds 1, 2 and 3 (each within the scatter of the next).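

At this position in this assay, extending 3-(dimethylamino)propyl to 4-(dimethylamino)butyl gives a 1.7-fold higher number from compound 1 to compound 3 (0.24 log units; within the scatter), so one added chain carbon, like 4-methylpiperazin-1-yl in place of dimethylamino, stays within the scatter. The two changes also land within the scatter of each other, with a 1.0-fold higher number from compound 2 to compound 3 (0.01 log units; within the scatter). No available evidence bears on a cause for this result.

Still open, on these data alone, are the shorter 2-(dimethylamino)ethyl chain and a chain ending in a hydroxyl group instead of an amine. As far as these compounds go, it also remains open whether any change at this position moves the number beyond the scatter.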